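Hydrogen in place of one methoxy on compound 3

A few compounds are considered here, and "the series" means these few. Any claim that something is new, unique, unknown or untested is made for them only; others in the source may bear on it.

In a functional assay (Homo sapiens) for antiproliferative activity, read by sulforhodamine B assay, with a stated time of 48 h (a higher number here means a weaker inhibitor, a lower number a stronger inhibitor), compound 1 `Cc1cccc(NS(=O)(=O)c2ccc(N3CCNC3=O)cc2)c1` gives 290 nM and compound 2 `Cc1cc(C)cc(NS(=O)(=O)c2ccc(N3CCNC3=O)cc2)c1` gives 260 nM on the shared core. Compound 3 `COc1cc(NS(=O)(=O)c2ccc(N3CCNC3=O)cc2)cc(OC)c1` gives 280 nM and stands within the scatter of both. Compound 4 `COc1cccc(NS(=O)(=O)c2ccc(N3CCNC3=O)cc2)c1` differs from compound 3 by hydrogen in place of methoxy on an aromatic carbon as hydrogen in place of methoxy on an aromatic carbon. For the measured compounds named here, no measured step shows this exact change. The closest is a 1.1-fold lower number from compound 1 to compound 2 (0.05 log units; within the scatter) for methyl in place of hydrogen on an aromatic carbon, and it lies within the scatter. On that basis no step beyond the scatter is expected in this assay and the estimated step is no change at the digits printed from compound 3 to compound 4 (within the scatter) in this series. For compound 4 the expected value is 280 nM with an estimated range from 160 nM to 480 nM as the working figure.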

Compound 4, half-maximal inhibitory concentration: 370 nM
The estimate for compound 4 lay 1.3-fold (0.12 log units) below the measured number, within the range that was stated.
By their numbers in this assay, from the lowest: compounds 2, 3, 1 and 4 (each within the scatter of the next).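

In this assay, hydrogen in place of one methoxy stays within the scatter (a 1.3-fold higher number from compound 3 to compound 4 (0.12 log units; within the scatter)). The two other comparisons with compound 4 also stay within it: methoxy in place of methyl (a 1.3-fold higher number from compound 1 to compound 4 (0.11 log units; within the scatter)) and 3-methoxyphenyl in place of 3,5-dimethylphenyl on a sulfonamide nitrogen (a 1.4-fold higher number from compound 2 to compound 4 (0.15 log units; within the scatter)). No available evidence bears on these small steps.

The aromatic groups shown carry only methyl or methoxy. From the compounds shown here alone, whether an amine, a carboxylic acid or a longer chain on this aromatic ring would give a step beyond the scatter remains open.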